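Pyridinyloxy series: methyl position shift, cytotoxicity outlook

The source may report more compounds than this note shows. Statements on the series, on what has been measured and on what is new or still open speak of the compounds shown alone.

Measured compounds and values in an ADME assay on PBMC cells (Homo sapiens) for cytotoxicity; on this read-out lower numbers stand for higher toxicity in this test and higher numbers for lower toxicity in this test:
- compound 1 `Cc1ccnc(OC(c2ccc(C(F)(F)F)cc2)C2CCN(C(C)CCNC(=O)c3c(Cl)cncc3Cl)CC2)c1` gives 33600 nM
- compound 2 `CC(CCNC(=O)c1c(Cl)cncc1Cl)N1CCC(C(=O)c2ccc(Br)cc2)CC1` gives 189000 nM
- compound 3 `CC(CCNC(=O)c1c(Cl)cncc1Cl)N1CCC(C(Oc2ncccc2Cl)c2ccc(C(F)(F)F)cc2)CC1` gives 16700 nM

Compound 1 stands second highest of the three numbers. Its nearest neighbour is compound 3, reached by a 2.0-fold lower number from compound 1 to compound 3 (0.30 log units; within the scatter), a step that stays within the scatter. Compound 2, which lacks the pyridinyloxy arm and carries a bromophenyl ketone instead, sits furthest away with a number that lies beyond the scatter from compound 1.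

Compound 4 `Cc1cccnc1OC(c1ccc(C(F)(F)F)cc1)C1CCN(C(C)CCNC(=O)c2c(Cl)cncc2Cl)CC1` is not yet measured in this assay. Against compound 1 the change is 3-methylpyridin-2-yl in place of 4-methylpyridin-2-yl on an oxygen on a saturated carbon. Within the data shown here, the single comparable step, the exchange of the 4-methylpyridin-2-yl for 3-chloropyridin-2-yl from compound 1 to compound 3, moved the number by an amount inside the scatter. Nothing else among the measured compounds addresses a change at this oxygen on a saturated carbon.

Among the measured compounds shown here, the step to compound 4 swaps one methylpyridinyl for another at the same place; the only related step was within the scatter, so no shift beyond the scatter is expected in either direction. Compound 4 is therefore expected near compound 1, at about 30000 nM, with a range from 15000 nM to 67000 nM, which means an expected step of a 1.1-fold lower number from compound 1 to compound 4 (0.05 log units; within the scatter).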

Compound 4, half-maximal cytotoxic concentration: 33000 nM
Beside the measured number, compound 4's estimate is 1.1-fold (0.04 log units) below it; measured number inside the range.
By their numbers in this assay, from the lowest: compounds 3, 4 and 1 (each within the scatter of the next); then compound 2.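

Working notes on the pyridinyloxy arm: in this assay the methyl shift alone gives a 1.0-fold lower number from compound 1 to compound 4 (0.01 log units; within the scatter) and so stays within the scatter, which makes this the first direct read on where the methyl sits on this ring. The exchange of chloro for methyl on an aromatic carbon, read on its own, gives a 2.0-fold higher number from compound 3 to compound 4 (0.30 log units; within the scatter) and also stays within the scatter, whereas the earlier step between compound 1 and compound 3 changed the group and its place together. Across compounds 1, 3 and 4, then, neither change separates from the scatter in this test, and no measurement at hand offers an explanation for that.

From the compounds shown here alone, these three compounds cover only methyl and chloro on the pyridin-2-yl ring, so it remains open whether a carboxylic acid, a primary amine or a longer alkyl chain there would also stay within the scatter. Also open, going by these compounds, is whether a phenyl ring in place of the pyridin-2-yl ring on the same oxygen would shift the number, and the same holds for the unsubstituted pyridin-2-yl group.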